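Fluoro added beside the retained nitro in the series

A few compounds are considered here, and "the series" means these few. Any claim that something is new, unique, unknown or untested is made for them only; others in the source may bear on it.

The series shares a core of compound 1 `O=c1c(-c2cccc([N+](=O)[O-])c2)nc2ccccc2n1Cc1ccccc1`, which in an assay on cells for activation of Cystic fibrosis transmembrane conductance regulator (Homo sapiens), read by fluorescence, with a stated time of 10 min (a higher number here means that more compound is needed for the effect, a lower number that less compound is needed), gives 9 nM. Within the data shown here, compound 1 holds the lowest number of the two measured so far; its nearest neighbour is compound 2 `O=c1c(-c2cccc(Br)c2)nc2ccccc2n1Cc1ccccc1`, which in this assay gives 330 nM. Among the measured compounds shown here, the one step established is a 37-fold higher number from compound 1 to compound 2 (1.56 log units; beyond the scatter), so the nitro group on the aromatic ring carries much of what compound 1 shows.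

Compound 3 `O=c1c(-c2ccc(F)c([N+](=O)[O-])c2)nc2ccccc2n1Cc1ccccc1` is the next compound for this assay. Its difference from compound 1 is fluoro in place of hydrogen on an aromatic carbon, the fluorine entering on an aromatic carbon of the six-membered ring, ortho to the nitro group and para to the large group. For the measured compounds named here, no measured step concerns this ring position; the step from compound 1 to compound 2 bears on it only indirectly, in that the nitro group is kept intact in compound 3. A single fluorine added with no change in donors, acceptors or charge is expected to move the number little, so the expected step of a 1.3-fold higher number from compound 1 to compound 3 (0.12 log units; within the scatter) is one within the scatter, with no clear direction. Compound 3 is therefore estimated at 12 nM in this assay, within a range of 3 nM to 45 nM.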

Compound 3, half-maximal effective concentration: 690 nM
Compound 3: middle estimate off by 58-fold (1.76 log units), on the low side, and the stated range ends below it.
By their numbers in this assay, from the lowest: compound 1; then compound 2; then compound 3.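

In this assay, the carbon ortho to a nitro group and para to a large group turns out to be highly sensitive: fluoro in place of hydrogen there gives a 77-fold higher number from compound 1 to compound 3 (1.88 log units; beyond the scatter), so keeping the nitro group intact does not by itself keep the low number of compound 1. This step is of similar size to a 37-fold higher number from compound 1 to compound 2 (1.56 log units; beyond the scatter), which shows that adding a single fluorine at this carbon weighs about as heavily in this assay as replacing the nitro group with bromo. Nothing available accounts for the size of this step.

The compounds shown leave open whether the step is specific to fluoro or would hold for other groups on this carbon, such as chloro, methyl or methoxy. Also open, going by these compounds, are whether fluoro on another carbon of the same ring gives a step of this size, and whether fluoro on this carbon has the same effect when bromo stands in place of the nitro group.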